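The compounds below may be only part of what the source reports. "The series", "measured", "known", "first", "only" and "open" are said of these compounds alone.

Of the compounds shown here, three that share a core have been measured in a functional assay on MDA-MB-435 cells (Homo sapiens) for cytotoxicity, read by MTT assay, with a stated time of 72 h; on this read-out lower numbers stand for stronger inhibition and higher numbers for weaker inhibition. Compound 1 `N[C@H]1CC[C@H](Nc2c(C(=O)NCc3ccc(F)cc3)nc(Br)c3cccnc23)CC1` gives 6000 nM, compound 2 `NCCNc1c(C(=O)NCc2ccc(F)cc2)nc(Br)c2cccnc12` gives 12000 nM, and compound 3 `CNCCCNc1c(C(=O)NCc2ccc(F)cc2)nc(Br)c2cccnc12` gives 11000 nM. Compound 3 does not separate from the other two: the comparisons are a 1.8-fold higher number from compound 1 to compound 3 (0.26 log units; within the scatter) and a 1.1-fold lower number from compound 2 to compound 3 (0.04 log units; within the scatter), while the remaining pair shows a 2.0-fold higher number from compound 1 to compound 2 (0.30 log units; within the scatter).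

Compound 4 `Cc1ccc(S(=O)(=O)Oc2c(C(=O)NCc3ccc(F)cc3)nc(Br)c3cccnc23)cc1` departs much further from this set: ((4-methylphenyl)sulfonyl)oxy in place of (3-(methylamino)propyl)amino on an aromatic carbon. Here ((4-methylphenyl)sulfonyl)oxy stands in place of (3-(methylamino)propyl)amino on an aromatic carbon, para to a bromo group. The measured steps bear on this change only in part. Going by the values given here, each swaps one amino-bearing group for another, and none replaces the whole group with a sulfonyl-containing one, so no measured step can simply be carried over. The best available anchor is compound 3 at 11000 nM, and no step beyond the scatter is expected in this assay, though with little confidence and with either direction open. The estimated change is a 1.1-fold lower number from compound 3 to compound 4 (0.04 log units; within the scatter). Compound 4 is expected at about 10000 nM, with an estimated range from 3000 nM to 30000 nM.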

Compound 4, half-maximal inhibitory concentration: > 20000 nM
Compound 4: a limit, no number; the forecaster's own chance of this, stated with the estimate: 20%; at least 2.0-fold (0.30 log units) between middle value and limit.
By their numbers in this assay, from the lowest: compounds 1, 3 and 2 (each within the scatter of the next). At a limit, above all of these: compound 4.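

Compound 4 is the only compound shown in which no amino-bearing group sits on this aromatic carbon, para to a bromo group; with ((4-methylphenyl)sulfonyl)oxy there, compound 4 reads > 20000 nM in this assay, which is a limit of the assay and not a number. The change clears the scatter in one comparison, an at least 3.3-fold higher number from compound 1 to compound 4 (0.52 log units; beyond the scatter), whereas the floors of the other two comparisons, an at least 1.8-fold higher number from compound 3 to compound 4 (0.25 log units; that floor lies within the scatter) and an at least 1.6-fold higher number from compound 2 to compound 4 (0.22 log units; that floor lies within the scatter), stay within it, so a real drop in inhibition is established only against the 4-aminocyclohexyl compound. The position of compound 4 at the top of the set rests on a limit and not on a measured number: the limit of > 20000 nM in this assay, at which 1 of the 4 values shown sits.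

The oxygen link, the sulfonyl and the 4-methylphenyl ring all enter together in compound 4, and the compounds shown cannot tell which of them matters. They also leave open how a hydroxyl group, a methoxy group or a longer amine chain on this carbon would read in this assay.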